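The compounds below may be only part of what the source reports. "The series", "measured", "known", "first", "only" and "open" are said of these compounds alone.

In an ADME assay on BaF3 cells (Mus musculus) for cytotoxicity, read by CellTiter-Glo and CCK-8 assay, with a stated time of 72 h (a lower number here means a stronger inhibitor of growth, a higher number a weaker inhibitor of growth), compound 1 (`C=CS(=O)(=O)NCc1ccc(C(=O)Nc2ccc(C)c(Nc3nccc(-c4cccnc4)n3)c2)cc1`) gives 7710 nM and compound 2 (`CCC(=O)NCc1cccc(C(=O)Nc2ccc(C)c(Nc3nccc(-c4cccnc4)n3)c2)c1`) gives 4750 nM as its reading. Those two numbers lie within the usual scatter of each other, so neither compound can be ranked over the other, and compound 1 simply sits at the same level as compound 2. Compound 3 (`C/C=C/C(=O)N(CCN(C)C)Cc1ccc(C(=O)Nc2ccc(C)c(Nc3nccc(-c4cccnc4)n3)c2)cc1`) keeps the core of compound 1 and differs in one place ((2-(dimethylamino)ethyl)((prop-1-en-1-yl)carbonyl)amino in place of (vinylsulfonyl)amino on a saturated chain carbon bound to an aromatic carbon), with (2-(dimethylamino)ethyl)((prop-1-en-1-yl)carbonyl)amino in place of (vinylsulfonyl)amino on a saturated chain carbon bound to an aromatic carbon. Among the measured compounds shown here, no measured pair shows what a swap of this kind does, so any forecast is loose. With compound 1 at 7710 nM as the starting level, a moderate shift toward a lower number, meaning somewhat stronger growth inhibition, is expected. The estimated size of that shift is a 2.6-fold lower number from compound 1 to compound 3 (0.41 log units; beyond the scatter) on this reasoning. In this assay the estimated value for compound 3 is 3000 nM (expected range 800 nM to 9000 nM).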

Compound 3, concentration for 50% growth inhibition: > 10000 nM
Compound 3: no number, only a limit (the forecaster's own chance of this, stated with the estimate: 10%); middle value at least 3.3-fold (0.52 log units) from the limit.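

In this assay compound 3 gives > 10000 nM, which is a limit of the assay and not a number. Putting (2-(dimethylamino)ethyl)((prop-1-en-1-yl)carbonyl)amino in place of (vinylsulfonyl)amino on a saturated chain carbon bound to an aromatic carbon gives an at least 1.2-fold higher number from compound 1 to compound 3 (0.11 log units; that floor lies within the scatter), so this swap brings no lower number, although the floor of the step alone does not prove a real rise. How far the step truly reaches cannot be told, because the reading is a limit: the limit of > 10000 nM in this assay, at which 1 of the 3 values shown sits.

The entering group differs from the leaving one in two ways at once, with a carbonyl in place of the sulfonyl and a 2-(dimethylamino)ethyl chain on the nitrogen, and these compounds do not separate the two. On these data alone, it stays open how the reading would respond to the same (prop-1-en-1-yl)carbonyl group with only a hydrogen or a methyl on that nitrogen, or to a carboxylic acid at the end of the chain in place of the dimethylamino group.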